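Triazole nitrogen substituent swap on a cyclopropyl core

The source may report more compounds than this note shows. Statements on the series, on what has been measured and on what is new or still open speak of the compounds shown alone.

Compound 1 `CCCCCc1ccc(C#Cc2c(-c3ccc(CCCCC)cc3)oc3nc(=O)n(Cc4cn(-c5ccc(Cl)cc5)nn4)cc23)cc1` in a functional assay on CFPAC-1 cells (Homo sapiens) for antiproliferative activity, read by MTT assay, with a stated time of 72 h (on this read-out higher numbers stand for weaker inhibition and lower numbers for stronger inhibition), sits at a limit, > 100000 nM.
Compound 2 `O=c1nc2oc(C3CC3)c(C#CC3CC3)c2cn1Cc1cn(Cc2ccccc2)nn1` in this assay gives 4590 nM.
Compound 3 `CCCCCc1ccc(C#Cc2c(-c3ccc(CCCCC)cc3)oc3nc(=O)n(Cc4cn(Cc5ccccc5)nn4)cc23)cc1` in this assay sits at a limit, > 100000 nM.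

Going by the values given here, compound 2 holds the only number among the three; the other two sit at the limit of > 100000 nM in this assay, at which 2 of the 3 values shown sit. From compound 3 to compound 1 the change is 4-chlorophenyl in place of benzyl on an aromatic nitrogen, and the step is a step that the two limits leave unreadable from compound 3 to compound 1. The difference between the core of compound 2 and that of compound 3 is not broken down here. Compound 4 `O=c1nc2oc(C3CC3)c(C#CC3CC3)c2cn1Cc1cn(-c2ccc(Cl)cc2)nn1` is not yet measured in this assay; it differs from compound 2 by 4-chlorophenyl in place of benzyl on an aromatic nitrogen, the same change as from compound 3 to compound 1. That earlier step gives no readable size to lean on, so the expectation rests on compound 2 and its value 4590 nM. A step of a 1.1-fold higher number from compound 2 to compound 4 (0.04 log units; within the scatter) is expected, keeping the two close. Compound 4 is estimated at 5000 nM, between 1500 nM and 20000 nM.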

Compound 4, half-maximal inhibitory concentration: 35400 nM
The estimate for compound 4 lay 7.1-fold (0.85 log units) below the measured number; measured number above the stated range.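

In this assay, placing 4-chlorophenyl in place of benzyl on an aromatic nitrogen gives a 7.7-fold higher number from compound 2 to compound 4 (0.89 log units; beyond the scatter), so on this core the change weakens inhibition beyond the scatter. The same change on the core shared by compound 3 and compound 1 cannot be read, because both compounds sit at a limit: the limit of > 100000 nM in this assay, at which 2 of the 4 values shown sit. Going by these compounds alone, the one readable step therefore comes from a single core, and it does not show whether the change carries over to another core, in size or in direction.

The compounds shown leave open whether the chlorine or the missing methylene link drives the step. An unsubstituted phenyl or a phenethyl group on that aromatic nitrogen would bear on this question.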